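Cytotoxicity notes: isobutyl to isopropyl on the shared core

A few compounds are considered here, and "the series" means these few. Any claim that something is new, unique, unknown or untested is made for them only; others in the source may bear on it.

Measured so far:
- compound 1 `CCC1(Cc2ccccc2)OS(=O)(=O)C=C1OCCCCc1ccccc1` gives >= 20000 nM in an ADME assay on HEL cells (Homo sapiens) for cytotoxicity, with a stated time of 3 days; a higher number here means that more compound is tolerated, a lower number that less compound is tolerated; this is a limit of the assay, not a number.
- compound 2 `CC(C)CC1(Cc2ccccc2)OS(=O)(=O)C=C1OCc1ccccc1` gives >= 80000 nM in this assay ; this too is a limit of the assay, not a number.

Compound 2 therefore stands at a limit in this assay, as the limit of >= 80000 nM in this assay, at which 1 of the 2 values shown sits, records. Compound 1 sits at its own limit, (the limit of >= 20000 nM in this assay, at which 1 of the 2 values shown sits). For the measured compounds named here, neither gives a number, and no step between the two is measured, so their pair shows only that both are tolerated up to where the assay stops.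

Compound 3 `CC(C)C1(Cc2ccccc2)OS(=O)(=O)C=C1OCc1ccccc1` differs from compound 2 by isopropyl in place of isobutyl on a saturated ring carbon. Going by the values given here, no measured step for a change of this kind exists. The estimated step is a number no higher from compound 2 to compound 3 (the limit leaves the size open) in this assay, none beyond the usual scatter. Compound 3 is expected to give about 80000 nM in this assay, in a range from 30000 nM to 200000 nM, most likely reported again as a limit rather than a number.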

Compound 3, minimum cytotoxic concentration: >= 80000 nM
Compound 3 gave a limit, no number (the forecaster's own chance of this, stated with the estimate: 80%); the middle value sits exactly at the limit.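

In this assay compound 2 and compound 3 both stand at a limit of the assay, not a number, so no step between them can be read: the limit of >= 80000 nM in this assay, at which 2 of the 3 values shown sit.

The compounds shown leave open the concentration at which any of compound 1, compound 2 or compound 3 becomes cytotoxic, and whether isopropyl and isobutyl differ at all.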